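A few compounds are considered here, and "the series" means these few. Any claim that something is new, unique, unknown or untested is made for them only; others in the source may bear on it.

Measured compounds:
compound 1 `CNC(=O)N1CCCc2ccc(NC(=O)c3cccc(-c4ccn(C)n4)c3)cc21`, 99.5%;
compound 2 `CNC(=O)N1CCCc2ccc(NC(=O)c3cccc(-c4ccccc4)c3)cc21`, 1.39%;
compound 3 `CNC(=O)N1CCCc2ccc(NC(=O)c3cccc(-c4ccn(S(C)(=O)=O)n4)c3)cc21`, 37%.

In a functional assay on MV4-11 cells (Homo sapiens) for antiproliferative activity, with a stated time of 6 days, tested at 6.25 uM (a higher number here means a stronger effect of the compound at the concentration tested, a lower number a weaker effect), compound 3 stands second highest of the three, below compound 1 and above compound 2. Compound 4 `CNC(=O)N1CCCc2ccc(NC(=O)c3cccc(-c4cnn(S(C)(=O)=O)c4)c3)cc21` differs from compound 3 by 1-(methylsulfonyl)-1H-pyrazol-4-yl in place of 1-(methylsulfonyl)-1H-pyrazol-3-yl on an aromatic carbon. Within the data shown here, no measured step changes how the same atoms are joined within this ring, so the nearest guidance is indirect: a number 62.5 percentage points lower from compound 1 to compound 3 (beyond the scatter) and a number 35.6 percentage points higher from compound 2 to compound 3 (beyond the scatter) both concern this position, and each was large. Since the methylsulfonyl pyrazole is kept, compound 4 is expected to stay near compound 3, with a number 2 percentage points lower from compound 3 to compound 4 (within the scatter) expected within the scatter. Compound 4 is therefore estimated at 35% in this assay, within a range of 10% to 65%.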

Compound 4, a percentage reported as inhibition, at one concentration (the size of the read-out at that concentration, not a potency): 18%
Estimate against measurement, compound 4: 17 percentage points above; measured number inside the range.
By their numbers in this assay, from the lowest: compound 2; then compound 4; then compound 3; then compound 1.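

In this assay, the same atoms joined differently are enough to shift the result: 1-(methylsulfonyl)-1H-pyrazol-4-yl in place of 1-(methylsulfonyl)-1H-pyrazol-3-yl gives a number 19 percentage points lower from compound 3 to compound 4 (beyond the scatter), so this position responds to how the ring is attached and not only to which group it carries. Against the other two groups, the new group gives a number 16.6 percentage points higher from compound 2 to compound 4 (beyond the scatter) and a number 81.5 percentage points lower from compound 1 to compound 4 (beyond the scatter), so it sits above phenyl but far below 1-methyl-1H-pyrazol-3-yl. Nothing available here explains these differences. Still open, from the compounds shown here alone, is whether 1-methyl-1H-pyrazol-4-yl would hold the level of compound 1 or lose ground in the same way, and what a pyrazole with a free ring nitrogen hydrogen would give.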